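The compounds below may be only part of what the source reports. "The series", "measured", "known", "first", "only" and "open" are said of these compounds alone.

In an ADME assay on MRC5 cells (Homo sapiens), read by MTT assay, with a stated time of 72 h (a lower number here means a stronger inhibitor, a higher number a weaker inhibitor), compound 3 `C#Cc1cn([C@@H]2O[C@H](CO)[C@@H](O)[C@H]2O)c2nc(N)nc(OC)c12` gives only a limit, > 100000 nM. Compound 1 `COc1nc(N)nc2c1c(-c1ccccc1)cn2[C@@H]1O[C@H](CO)[C@@H](O)[C@H]1O` likewise reaches only a limit in this assay, > 100000 nM. Compound 2 `Nc1nc(N)c2c(-c3ccco3)cn([C@@H]3O[C@H](CO)[C@@H](O)[C@H]3O)c2n1` also stops at a limit in this assay, > 100000 nM. Thus compound 3 stands where all three measured values sit, because the limit of > 100000 nM in this assay, at which 3 of the 3 values shown sit, marks the point none of them pass. The change to compound 4 `COc1nc(N)nc2c1c(-c1ccco1)cn2[C@@H]1O[C@H](CO)[C@@H](O)[C@H]1O` is furan-2-yl in place of ethynyl on an aromatic carbon. Within the data shown here, the one measured step that touches this position, a step that the two limits leave unreadable from compound 1 to compound 3, cannot be read as to size. Among the measured compounds shown here, no step in this assay is therefore known to move the value out of the scatter. Compound 4 is expected to give a limit-bound value of about 150000 nM, within 60000 nM to 400000 nM, an expected step that the limit leaves unreadable from compound 3 to compound 4.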

Compound 4, half-maximal inhibitory concentration: 89700 nM
Compound 4: the middle estimate sits 1.7-fold (0.22 log units) above what was measured; the measured number falls inside the stated range.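

In this assay compound 4 is the only one shown that gives a number and not a limit. Furan-2-yl on this aromatic carbon gives an at least 1.1-fold lower number from compound 3 to compound 4 (0.04 log units; that floor lies within the scatter) and an at least 1.1-fold lower number from compound 1 to compound 4 (0.04 log units; that floor lies within the scatter), while methoxy in place of amino gives an at least 1.1-fold lower number from compound 2 to compound 4 (0.04 log units; that floor lies within the scatter), so each step is only a floor and none is shown to pass the scatter. The other compounds stay at a single limit: the limit of > 100000 nM in this assay, at which 3 of the 4 values shown sit.

From the compounds shown here alone, how large these steps really are remains open. So does what an amine or a longer chain on this aromatic carbon would give in this assay.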